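Ester for amide on the carbonyl carbon

A few compounds are considered here, and "the series" means these few. Any claim that something is new, unique, unknown or untested is made for them only; others in the source may bear on it.

Measured compounds in an assay on HL-60 cells for agonist activity at vitamin D3 receptor (Homo sapiens), read by microscopy, with a stated time of 96 h; on this read-out higher numbers stand for an effect only at larger amounts of compound and lower numbers for an effect already at smaller amounts:
compound 1 `CCn1c(C(=O)NCCCN(C)C)ccc1C(CC)(CC)c1ccc(OCC(=O)C(C)(C)C)c(C)c1` gives 96 nM
compound 2 `CCn1c(C(=O)NCC(OC)OC)ccc1C(CC)(CC)c1ccc(OCC(=O)C(C)(C)C)c(C)c1` gives 130 nM

Compound 2 sits beside compound 1, the two within the usual scatter of one another, as a 1.4-fold higher number from compound 1 to compound 2 (0.13 log units; within the scatter) shows. Compound 3 `C#CCCOC(=O)c1ccc(C(CC)(CC)c2ccc(OCC(=O)C(C)(C)C)c(C)c2)n1CC` is not yet measured; it differs from compound 2 by (but-3-yn-1-yl)oxy in place of (2,2-dimethoxyethyl)amino on a carbonyl carbon. Within the data shown here, no measured step alters the group on the carbonyl carbon itself; the only step available exchanged the chain on the amide nitrogen and stayed within scatter, so it bears on this change only loosely. Compound 3 is therefore expected to give 200 nM (range 50 nM to 800 nM), an estimated step of a 1.5-fold higher number from compound 2 to compound 3 (0.19 log units; within the scatter) in this assay, with no direction firmly expected.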

Compound 3, half-maximal effective concentration: 28800 nM
Beside the measured number, compound 3's estimate is 140-fold (2.16 log units) below it; measured number above the stated range.
By their numbers in this assay, from the lowest: compounds 1 and 2 (each within the scatter of the next); then compound 3.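

In this assay the group on the carbonyl carbon proves far from indifferent: (but-3-yn-1-yl)oxy gives a 220-fold higher number from compound 2 to compound 3 (2.35 log units; beyond the scatter) and a 300-fold higher number from compound 1 to compound 3 (2.48 log units; beyond the scatter) while the two amino chains stay within the scatter of each other. The position thus accepts a change of chain on the amide nitrogen, yet not this exchange of an amino group for an oxy group. Nothing at hand accounts for the size of these steps.

Going by these compounds, whether the steps follow the ester oxygen or the but-3-yn-1-yl chain stays open, as both change together here. A (but-3-yn-1-yl)amino group on the carbonyl carbon would separate the two, and a methoxy group or a carboxylic acid there would show whether other non-amide groups behave alike.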